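This account rests on a few compounds, and the source may have more. Where it says the series, first, only, none or still open, it means among the compounds named here.

Measured in a functional assay on HeLa cells (Homo sapiens) for inhibition, read by MTT assay, with a stated time of 72 h; a lower number here means a stronger inhibitor, a higher number a weaker inhibitor:
- compound 1 `O=[N+]([O-])c1ccccc1Nc1nnc(-c2c[nH]c3ccccc23)o1`: 300 nM
- compound 2 `O=[N+]([O-])c1ccc(Nc2nnc(-c3c[nH]c4ccccc34)o2)cc1`: 1760 nM

Compound 2 holds the higher of the two numbers, and the gap down to compound 1 lies beyond the scatter. Compound 3 `Clc1ccc(Nc2nnc(-c3c[nH]c4ccccc34)o2)cc1` differs from compound 2 as follows: chloro in place of nitro on an aromatic carbon. This puts chloro in place of nitro on an aromatic carbon, para to a large group. Within the data shown here, no measured step covers this exchange, so the expectation is loose. A modest move to a lower number in this assay is expected, close to the scatter in size. The expected change is a 2.0-fold lower number from compound 2 to compound 3 (0.29 log units; within the scatter). For compound 3 the estimated value is 900 nM, with an expected range of 250 nM to 3200 nM.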

Compound 3, half-maximal inhibitory concentration: 3800 nM
Compound 3: the middle estimate sits 4.2-fold (0.63 log units) below what was measured, outside the stated range (above it).
By their numbers in this assay, from the lowest: compound 1; then compound 2; then compound 3.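

Chloro in place of nitro on this aromatic carbon, para to a large group, gives a 2.2-fold higher number from compound 2 to compound 3 (0.33 log units; beyond the scatter) in this assay and so does not improve on nitro here. The modest size of the step shows that activity in this assay does not depend wholly on nitro at this position. No measured property bears on this result.

As far as these compounds go, whether an amine or a methoxy group here would give a lower number than nitro stays open. So does the effect of chloro at the position that nitro holds in compound 1.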